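Swapping a saturated ring for an anilino group on the core

The source may hold more compounds than are shown below. What is called first, only, known or untested is meant among the compounds shown, and "the series" means these compounds.

Compound 3 `CC1CCN(c2nc(Cl)nc3c2ncn3Cc2ccc(C(=O)Nc3ccccc3N)cc2)CC1` stands second highest of the three numbers in a functional assay on A-375 cells (Homo sapiens) for antiproliferative activity, read by CCK-8 assay, with a stated time of 72 h (on this read-out higher numbers stand for weaker inhibition and lower numbers for stronger inhibition), where it gives 4240 nM. For the measured compounds named here, its nearest neighbour, compound 1 `CN1CCN(c2nc(Cl)nc3c2ncn3Cc2ccc(C(=O)Nc3ccccc3N)cc2)CC1`, gives 1600 nM; the only directly comparable step, a 2.7-fold higher number from compound 1 to compound 3 (0.42 log units; beyond the scatter), shows that replacing the 4-methylpiperazin-1-yl group with the 4-methylpiperidin-1-yl group costs a modest amount of potency. Compound 2 `Nc1ccccc1NC(=O)c1ccc(Cn2cnc3c(Nc4ccc(-c5ccccn5)cc4)nc(Cl)nc32)cc1`, which carries an arylamino group at the same site, gives 18500 nM, the weakest of the three. Compound 4 `Nc1ccccc1NC(=O)c1ccc(Cn2cnc3c(Nc4cccc(Cl)c4)nc(Cl)nc32)cc1` differs from compound 3 by (3-chlorophenyl)amino in place of 4-methylpiperidin-1-yl on an aromatic carbon. Since compound 2 with its arylamino group gave 18500 nM, compound 4 is expected to be weaker than compound 3, with an estimated step of a 2.1-fold higher number from compound 3 to compound 4 (0.33 log units; beyond the scatter). The estimate for compound 4 is 9000 nM, ranging from 3500 nM to 25000 nM.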

Compound 4, half-maximal inhibitory concentration: 6080 nM
Beside the measured number, compound 4's estimate is 1.5-fold (0.17 log units) above it, and the stated range covers the measured number.
By their numbers in this assay, from the lowest: compound 1; then compounds 3 and 4 (each within the scatter of the next); then compound 2.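

In this assay, a (3-chlorophenyl)amino group at this position performs on a par with the saturated 4-methylpiperidin-1-yl ring, with a 1.4-fold higher number from compound 3 to compound 4 (0.16 log units; within the scatter), so an arylamino link alone does not set the number. What sits on that nitrogen does matter: 3-chlorophenyl in place of 4-(pyridin-2-yl)phenyl gives a 3.0-fold lower number from compound 2 to compound 4 (0.48 log units; beyond the scatter). The 4-methylpiperazin-1-yl group still compares better, with a 3.8-fold higher number from compound 1 to compound 4 (0.58 log units; beyond the scatter).

No measurement here explains why these numbers differ. From the compounds shown here alone, whether a morpholine ring or an unsubstituted phenylamino group at this position would come closer to compound 1 remains open.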